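Hydrogen in place of methyl on the ether oxygen of compound 1

The compounds below may be only part of what the source reports. "The series", "measured", "known", "first", "only" and "open" are said of these compounds alone.

Compound 1 `COc1cc(/C=C/c2ccc(C(F)(F)F)cc2)ccc1/C=C/c1ccc(C(F)(F)F)cc1`: > 7
Compound 2 `COc1cc(/C=C/c2ccc(OC(F)(F)F)cc2)ccc1/C=C/c1ccc(OC(F)(F)F)cc1`: > 7
Compound 3 `COc1cc(/C=C/c2ccc(C(F)(F)C(F)F)cc2)ccc1/C=C/c1ccc(C(F)(F)C(F)F)cc1`: > 7

In a physicochemical assay for lipophilicity, read by HPLC (on this read-out lower numbers stand for lower lipophilicity and higher numbers for higher lipophilicity), the value of compound 1 is a limit of the assay and not a number. The same holds for compound 2. It also holds for compound 3. Going by the values given here, all three measured compounds therefore stand at the limit of > 7 in this assay, at which 3 of the 3 values shown sit, and no step between measured compounds can be read from these data; how far compound 1 actually lies beyond the limit is unknown.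

Compound 4 `Oc1cc(/C=C/c2ccc(C(F)(F)F)cc2)ccc1/C=C/c1ccc(C(F)(F)F)cc1` has not been measured in this assay. It differs from compound 1 in one place: hydrogen in place of methyl on an oxygen on an aromatic ring. Among the compounds with values here, since no measured step of this kind exists here, the expectation rests on the structural change alone. The step in this assay is expected to be a number at least 0.20 log units lower from compound 1 to compound 4 (that floor lies within the scatter), a moderate move toward lower lipophilicity. Compound 4 is therefore expected to give about 6.8, with a range from 6.2 to 7.5. Because compound 1 gives > 7, which is a limit of the assay and not a number, the result for compound 4 may again be reported as a limit rather than a number.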

Compound 4, partition coefficient: 6.18
Compound 4: the middle estimate sits 0.62 log units above what was measured; measured number outside the range, below it.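

In this assay, the change from methoxy to hydroxy on the aromatic ring gives a number at least 0.82 log units lower from compound 1 to compound 4 (beyond the scatter). Compound 1 gives > 7, which is a limit of the assay and not a number, so the step has a floor but no known full size. This position is the first shown where a single change brings the read-out away from the limit, and compound 4 is the only compound shown with a number: the limit of > 7 in this assay, at which 3 of the 4 values shown sit.

Steps among compound 1, compound 2 and compound 3 cannot be read, and whether methoxy to hydroxy gives a step of similar size on the core of compound 2 or compound 3 stays open. Also open, on these data alone, is what a longer chain on that oxygen, or an amine carried on such a chain, would do to the read-out.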